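A few compounds are considered here, and "the series" means these few. Any claim that something is new, unique, unknown or untested is made for them only; others in the source may bear on it.

Measured compounds:
Compound 1 `CC#C[C@@H](CC(=O)O)c1ccc(OCc2ccc3nc(-c4ccc(OC(F)F)cc4)nn3c2)cc1` gives 98 nM in an assay on cells for agonist activity at Free fatty acid receptor 1 (Rattus norvegicus), read by a beta-galactosidase reporter and beta-arrestin recruitment, with a stated time of 90 min, in the presence of a further agent that is not named here; a higher number here means that more compound is needed for the effect, a lower number that less compound is needed.
Compound 2 `CC#C[C@@H](CC(=O)O)c1ccc(OCc2ccc3nc(-c4c(C)cc(OCCCS(C)(=O)=O)cc4C)nn3c2)cc1` gives 95 nM in this assay.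
Compound 3 `CC#C[C@@H](CC(=O)O)c1ccc(OCc2ccc3nc(-c4ccc(C(C)C)cc4)nn3c2)cc1` gives 30 nM in this assay.

Compound 3 has the lowest number of the three, and its gaps to compound 1 and to compound 2 both lie beyond the scatter. Compound 4 `CC#C[C@@H](CC(=O)O)c1ccc(OCc2ccc3nc(-c4ccc(C#N)cc4)nn3c2)cc1` differs from it by cyano in place of isopropyl on an aromatic carbon. Among the compounds with values here, the one measured step at this position is a 3.3-fold lower number from compound 1 to compound 3 (0.51 log units; beyond the scatter), which introduced the isopropyl that now leaves. Compound 2 carries a different group at the same place and sits close to compound 1. Removing the isopropyl is therefore expected to move the number back toward those of compounds 1 and 2, a modest step up of about a 2.7-fold higher number from compound 3 to compound 4 (0.43 log units; beyond the scatter). Compound 4 is estimated at 80 nM, with a range from 30 nM to 220 nM.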

Compound 4, half-maximal effective concentration: 216 nM
Compound 4: middle estimate off by 2.7-fold (0.43 log units), on the low side; the range from low to high includes it.
By their numbers in this assay, from the lowest: compound 3; then compounds 2 and 1 (each within the scatter of the next); then compound 4.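

With cyano in place of isopropyl on the aromatic carbon, this assay shows a 7.2-fold higher number from compound 3 to compound 4 (0.86 log units; beyond the scatter), and cyano in place of difluoromethoxy shows a 2.2-fold higher number from compound 1 to compound 4 (0.34 log units; beyond the scatter), so the change does more than return the number to the level of compound 1. Among compounds 1, 3 and 4, which differ only at this place, the number rises from isopropyl through difluoromethoxy to cyano, with every gap beyond the scatter. Nothing given here explains this order. The compounds shown leave open how a tert-butyl group or a primary amide at this place would compare with isopropyl and cyano.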